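The compounds below may be only part of what the source reports. "The series", "measured", "known", "first", "only" and "open" are said of these compounds alone.

Measured compounds:
Compound 1 `Fc1ccc(C2=NN(C3=NC(c4ccccc4)CS3)C(c3cccc4ccccc34)C2)cc1` gives 22700 nM in a functional assay on BGC-823 cells (Homo sapiens) for inhibition, read by CCK-8 assay, with a stated time of 48 h; a lower number here means a stronger inhibitor, a higher number a weaker inhibitor.
Compound 2 `Cc1ccc(C2=NN(C3=NC(c4ccccc4)CS3)C(c3cccc4ccccc34)C2)cc1C` gives 8460 nM in this assay.
Compound 3 `O=C1CSC(N2N=C(c3ccc(F)cc3)CC2c2ccc3ccccc3c2)=N1` gives 14900 nM in this assay.

Compounds 1 and 2 share one core and differ in one place: 3,4-dimethylphenyl in place of 4-fluorophenyl on a carbon with a double bond to nitrogen. That change made a step of a 2.7-fold lower number from compound 1 to compound 2 (0.43 log units; beyond the scatter). Compound 3 has a different core; the difference between the two cores is not broken down here. Compound 4 `Cc1ccc(C2=NN(C3=NC(=O)CS3)C(c3ccc4ccccc4c3)C2)cc1C` has not yet been measured. It differs from compound 3 as follows: 3,4-dimethylphenyl in place of 4-fluorophenyl on a carbon with a double bond to nitrogen. This is the same kind of change as that from compound 1 to compound 2, but the surroundings are not identical: in compound 1 the place lies two ring bonds from the ring atom that bears a naphthalen-1-yl group, whereas in compound 3 it lies two ring bonds from the ring atom that bears a group of 6 heavy atoms. Because the step of a 2.7-fold lower number from compound 1 to compound 2 (0.43 log units; beyond the scatter) ran toward a lower number, a step of similar direction and size, a 2.5-fold lower number from compound 3 to compound 4 (0.40 log units; beyond the scatter), is expected here, though the different core leaves this uncertain. Compound 4 is therefore estimated at 6000 nM, with a likely range from 2500 nM to 15000 nM.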

Compound 4, half-maximal inhibitory concentration: 6020 nM
Compound 4: the middle estimate sits 1.0-fold (0.00 log units) below what was measured, and the stated range covers the measured number.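

In this assay, putting 3,4-dimethylphenyl in place of 4-fluorophenyl gave a 2.5-fold lower number from compound 3 to compound 4 (0.39 log units; beyond the scatter), so the change again lowered the number on a second core. Set side by side, the two steps agree: the same change on two cores in this assay, a 2.7-fold lower number (0.43 log units; beyond the scatter) from compound 1 to compound 2 and a 2.5-fold lower number (0.39 log units; beyond the scatter) from compound 3 to compound 4, 1.1-fold (0.04 log units) apart, within the scatter of two such steps. This shows that the change carried over in direction and size between these two cores in this one cell assay, but two pairs cannot show that it would hold on any further core, and they do not explain why the number moves or separate the loss of the fluorine from the gain of the two methyl groups.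

The compounds shown carry only these two groups at this place, so it remains open how a phenyl ring bearing a single methyl group, a methoxy group, an amine or a carboxylic acid would behave there. It also remains open how much each difference between the two cores contributes on its own, since no pair shown isolates them.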